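Cyclohexyl to pyrazin-2-yl: an expected step at the limit

This account rests on a few compounds, and the source may have more. Where it says the series, first, only, none or still open, it means among the compounds named here.

Compound 2 `O=C(NCCCCCCS)c1cc(C2CCCCC2)n[nH]1` stands only at a limit: in a functional assay on HCT-116 cells (Homo sapiens) for inhibition, read by MTT assay, with a stated time of 96 h (a lower number here means a stronger inhibitor of growth, a higher number a weaker inhibitor of growth), compound 2 gives > 50000 nM, which is a limit of the assay and not a number. Two of the three values shown sit at that limit (the limit of > 50000 nM in this assay, at which 2 of the 3 values shown sit). Compound 1 `C=CCOC(=O)SCCCCCCNC(=O)c1cc(-c2ccncc2)n[nH]1` carries an allyloxycarbonyl on its sulfur, and in this assay compound 1 gives 32900 nM. Compound 3 `CSCCCCCCNC(=O)c1cc(-c2ccncc2)n[nH]1` gives in this assay > 50000 nM, again a limit of the assay. For the measured compounds named here, the only measured step, an at least 1.5-fold higher number from compound 1 to compound 3 (0.18 log units; that floor lies within the scatter), concerns the group on the sulfur and so does not bear on the change considered here. Compound 4 `O=C(NCCCCCCS)c1cc(-c2cnccn2)n[nH]1` differs from compound 2 by pyrazin-2-yl in place of cyclohexyl on an aromatic carbon. Going by the values given here, no measured pair isolates this exchange, and compound 1 and compound 3 differ from compound 2 in more than one place, so they give no clean guide. Compound 4 is therefore expected to give about 45000 nM, with a range from 15000 nM to 120000 nM, and a limit may again be all that is reported. That corresponds to an expected at least 1.1-fold lower number from compound 2 to compound 4 (0.04 log units; that floor lies within the scatter).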

Compound 4, concentration for 50% growth inhibition: > 50000 nM
Compound 4 was reported as a limit (the forecaster's own chance of this, stated with the estimate: 55%); at least 1.1-fold (0.04 log units) between middle value and limit.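

In this assay compound 4 gives > 50000 nM as a limit of the assay and not a number. For the compounds shown here, compound 2 also stands at a limit, so no step between compound 2 and compound 4 can be read: the limit of > 50000 nM in this assay, at which 3 of the 4 values shown sit. The compounds shown leave open whether pyrazin-2-yl in place of cyclohexyl changes growth inhibition at all.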